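Two Measured Compounds and One Open Ring Exchange

The compounds below may be only part of what the source reports. "The series", "measured", "known", "first", "only" and "open" are said of these compounds alone.

Measured in an ADME assay on microsomes from liver (Rattus norvegicus) for metabolic stability; on this read-out lower numbers stand for a shorter-lived compound and higher numbers for a longer-lived compound:
- Compound 1 `CC(C)C(/C=C1\NC(=O)NC1=O)c1ccc(-c2ccc3cccc(F)c3c2)[nH]c1=O`: 1.46 h
- Compound 2 `CC(C)C(c1ccc(-c2ccc3cccc(F)c3c2)[nH]c1=O)C1SC(=O)NC1=O`: 0.76 h

In this assay compound 2 gives 0.76 h, which lies within the scatter of compound 1 at 1.46 h. The two therefore cannot be ranked on these numbers. Compound 3 `C/C(=C1/OC(=O)NC1=O)C(c1ccc(-c2ccc3cccc(F)c3c2)[nH]c1=O)C(C)C` has not yet been measured, and it differs from compound 2 as follows: a group of 9 heavy atoms (5 carbon, 1 nitrogen, 3 oxygen; one five-membered non-aromatic ring with 2 hetero atoms) in place of a group of 7 heavy atoms (3 carbon, 1 nitrogen, 2 oxygen, 1 sulfur; one five-membered non-aromatic ring with 2 hetero atoms), on a saturated chain carbon bound to an aromatic carbon and a saturated chain carbon. Going by the values given here, one measured step bears on this change: a 1.9-fold lower number from compound 1 to compound 2 (0.28 log units; within the scatter). That step also exchanged a ring group at this kind of carbon, and it stayed within the scatter. The data hold no measurement of the entering group, so on this single step no change beyond the scatter is expected in this assay. The expected step is a 1.3-fold higher number from compound 2 to compound 3 (0.12 log units; within the scatter). For compound 3 the estimate is 1 h, with an expected range from 0.45 h to 2.2 h.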

Compound 3, half-life: > 3 h
Compound 3: no number, only a limit; the forecaster's own chance of this, stated with the estimate: 3%; middle value at least 3.0-fold (0.47 log units) from the limit.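

In this assay compound 3 reads > 3 h, which is a limit of the assay and not a number: the limit of > 3 h in this assay, at which 1 of the 3 values shown sits. At the saturated chain carbon bound to an aromatic carbon and a saturated chain carbon, replacing the 2,4-dioxo-1,3-thiazolidin-5-yl group with the entering ring group gives an at least 3.9-fold higher number from compound 2 to compound 3 (0.59 log units; beyond the scatter), and the other exchange of ring groups gives an at least 2.0-fold higher number from compound 1 to compound 3 (0.31 log units; beyond the scatter). A ring exchange at this carbon can therefore move the half-life beyond the scatter, which the earlier pair of compounds did not show.

From the compounds shown here alone, how far compound 3 lies past its limit stays open, as does which of the differences in the entering group, in its atoms or its double bonds, carries the step. Going by these compounds, whether an amine or a carboxylic acid at this carbon would give a similar half-life also remains open.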